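Swapping a carbamoyl amino group for 4-fluorophenyl

The compounds below may be only part of what the source reports. "The series", "measured", "known", "first", "only" and "open" are said of these compounds alone.

In a functional assay on MIA PaCa-2 cells (Homo sapiens) for inhibition, read by MTT assay, with a stated time of 72 h (on this read-out higher numbers stand for weaker inhibition and lower numbers for stronger inhibition), compound 1 `COc1cc(NC(C)CCCNC(=O)Nc2cccc(Cl)c2)c2ncccc2c1` gives 21000 nM. Compound 2 `COc1cc(NC(C)CCCNC(=O)Nc2ccc(Br)cc2)c2ncccc2c1` gives 23000 nM, and the two stand close together, with a 1.1-fold higher number from compound 1 to compound 2 (0.04 log units; within the scatter). Compound 3 `COc1cc(NC(C)CCCNC(=O)NNC(=O)Nc2ccc(F)cc2)c2ncccc2c1` gives >= 250000 nM, which is a limit of this assay and not a number.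

Compound 4 `COc1cc(NC(C)CCCNC(=O)Nc2ccc(F)cc2)c2ncccc2c1` differs from compound 3 in one place, on an amide-type nitrogen whose other neighbours are: carbonyl carbon. There, 4-fluorophenyl stands in place of ((4-fluorophenyl)carbamoyl)amino (4-fluorophenyl in place of ((4-fluorophenyl)carbamoyl)amino on an amide-type nitrogen). Compound 4 therefore carries a halogen-bearing phenyl directly on that nitrogen, as compound 1 and compound 2 do, and exchanging one such phenyl for the other gave only a 1.1-fold higher number from compound 1 to compound 2 (0.04 log units; within the scatter). The steps that bring in the carbamoyl amino group were both large, with an at least 11-fold higher number from compound 1 to compound 3 (1.07 log units; beyond the scatter) and an at least 10-fold higher number from compound 2 to compound 3 (1.03 log units; beyond the scatter), so taking it away should run the opposite way. A large step toward stronger inhibition is therefore expected, an at least 11-fold lower number from compound 3 to compound 4 (1.05 log units; beyond the scatter). Compound 4 is estimated at 22000 nM, with an expected range from 10000 nM to 50000 nM.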

Compound 4, half-maximal inhibitory concentration: 21000 nM
Compound 4: middle estimate off by 1.0-fold (0.02 log units), on the high side; the range from low to high includes it.
By their numbers in this assay, from the lowest: compounds 1, 4 and 2 (each within the scatter of the next). At a limit, above all of these: compound 3.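

Placing the 4-fluorophenyl directly on the amide-type nitrogen gives an at least 11-fold lower number from compound 3 to compound 4 (1.07 log units; beyond the scatter). Compound 3 and compound 4 both carry this fluorinated ring, so this single change ties the large difference to the ((4-fluorophenyl)carbamoyl)amino group as a whole, and not to a change of halogen. The halogen swaps themselves stay small in this assay: fluoro in place of bromo gives a 1.1-fold lower number from compound 2 to compound 4 (0.04 log units; within the scatter), and 4-fluorophenyl in place of 3-chlorophenyl gives no change at the digits printed from compound 1 to compound 4 (within the scatter).

The value of compound 3 is a limit and not a number, so the full size of its step stays unknown: the limit of >= 250000 nM in this assay, at which 1 of the 4 values shown sits.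

Still open, from the compounds shown here alone, is how an unsubstituted phenyl, or one carrying a methoxy or nitrile group, would compare at this place. Also open, going by these compounds, is whether a cyclohexyl group or a longer chain on that nitrogen would give stronger inhibition than compounds 1, 2 and 4.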